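This account rests on a few compounds, and the source may have more. Where it says the series, first, only, none or still open, it means among the compounds named here.

In a functional assay on HL-60 cells (Homo sapiens) for cytotoxicity, with a stated time of 24 h (on this read-out lower numbers stand for higher toxicity in this test and higher numbers for lower toxicity in this test), compound 1 `Cc1ccc(/C=C2\CCC/C(=C\c3ccccc3[N+](=O)[O-])C2=O)cc1` gives 11000 nM, while compound 2 `O=C1/C(=C/c2ccc(Cl)cc2)CCC/C1=C\c1cccc([N+](=O)[O-])c1` gives 3200 nM. Compound 2 therefore holds the lower of the two numbers, and the gap between them is larger than repeat measurements would normally produce. These two compounds differ in more than one place, so they do not show what any single change does. Compound 3 `COc1ccc(/C=C2\CCC/C(=C\c3cccc([N+](=O)[O-])c3)C2=O)cc1` has not been measured yet. It departs from compound 2 in one place, with methoxy in place of chloro on an aromatic carbon, para to a large group (methoxy in place of chloro on an aromatic carbon). Within the data shown here, no measured pair shows this swap, so only a small shift toward a higher number, within the usual scatter, is expected: a 1.4-fold higher number from compound 2 to compound 3 (0.15 log units; within the scatter). In this assay, the expected value for compound 3 is 4500 nM, with an estimated range of 1800 nM to 11000 nM.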

Compound 3, half-maximal cytotoxic concentration: 7200 nM
For compound 3 the middle estimate is 1.6-fold (0.20 log units) below the measured one; the measured number falls inside the stated range.
By their numbers in this assay, from the lowest: compound 2; then compounds 3 and 1 (each within the scatter of the next).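

Among these compounds, compound 2 and compound 3 give the first comparison here that isolates a single change: in this assay, replacing 4-chlorophenyl with 4-methoxyphenyl gives a 2.3-fold higher number from compound 2 to compound 3 (0.35 log units; beyond the scatter) and thus lowers the toxicity in this test. The step is modest, but it shows that the read-out responds to the group at this position on the aromatic ring, with chloro giving the more toxic compound of this pair. No accompanying measurement explains the difference, so its cause remains unknown.

As far as these compounds go, it remains open whether an amine or a carboxylic acid at this position would move the number further than methoxy does. The compounds shown also cannot tell whether the same swap would have a similar effect with the nitro group placed as in compound 1.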